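The source may report more compounds than this note shows. Statements on the series, on what has been measured and on what is new or still open speak of the compounds shown alone.

Of the compounds shown here, two in this set have already been tested. Compound 1 `N#CC1=C(N)OC(c2c[nH]c3ccccc23)=C(C#N)C1c1ccccc1F` was reported in a functional assay, tested at 400 ug/mL (on this read-out lower numbers stand for a weaker effect and higher numbers for a stronger effect at the one concentration tested), as "not active" (no number reported), with no number given, so it counts as an entry without a value rather than a low value. Compound 2 `N#CC1=C(N)OC(c2c[nH]c3ccccc23)=C(C#N)C1c1ccc(Br)cc1` was tested in the same way, and in this assay compound 2 gives 22.7%. Within the data shown here, that makes compound 2 the only compound here with a number attached; there is nothing else to place it above or below, so it simply stands alone on the scale.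

The next compound, compound 3 `N#CC1=C(N)OC(c2c[nH]c3ccccc23)=C(C#N)C1c1ccc2ccccc2c1`, differs from compound 2 in a single place: naphthalen-2-yl in place of 4-bromophenyl on a saturated ring carbon. Among the measured compounds shown here, no pair of measured compounds differing in one place is available, so the size of this kind of step is unknown from the data. The step expected here, a number 4.3 percentage points higher from compound 2 to compound 3 (within the scatter), is estimated to be small, within the usual scatter of repeated measurements, with no clear direction. On that basis compound 3 is expected to give about 27% in this assay, somewhere between 12% and 45%.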

Compound 3, a percentage reported as activity, at one concentration (the size of the read-out at that concentration, not a potency): "not active" (no number reported)
Nothing numeric was reported for compound 3; no gap can be computed for the estimate.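

Among these compounds, no step in size can be read from compound 2 to compound 3, since compound 3 carries no number in this assay and so cannot be set against compound 2 at 22.7%. Nothing here explains that result. The compounds shown leave open how much swapping 4-bromophenyl for naphthalen-2-yl changes the read-out.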